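The compounds below may be only part of what the source reports. "The series", "measured", "known", "first", "only" and "open" are said of these compounds alone.

Working notes on the series in an assay on CHO cells for binding affinity to Substance-P receptor (Homo sapiens), read by radioligand binding; on this read-out higher numbers stand for weaker inhibition and lower numbers for stronger inhibition. Compound 1 `O=C(CN(N1CCN(Cc2ccccc2)CC1)N1CCN(Cc2ccccc2)CC1)N1CCN(Cc2cc(C(F)(F)F)cc(C(F)(F)F)c2)CC1c1ccc(Cl)c(Cl)c1` gives 28 nM in this assay. Compound 2 `O=C(CN(NC1CCN(Cc2ccccc2)CC1)NC1CCN(Cc2ccccc2)CC1)N1CCN(Cc2cc(C(F)(F)F)cc(C(F)(F)F)c2)CC1c1ccccc1` gives 17 nM in this assay. Compound 2 holds the lower of the two numbers, but the gap to compound 1 lies within the scatter, so the two values show no difference that can be relied on. Compound 3 `O=C(CN(NC1CCN(Cc2ccccc2)CC1)NC1CCN(Cc2ccccc2)CC1)N1CCN(Cc2cc(C(F)(F)F)cc(C(F)(F)F)c2)CC1c1ccc(Cl)c(Cl)c1` has not yet been measured in this assay. It differs from compound 2 by 3,4-dichlorophenyl in place of phenyl on a saturated ring carbon. For the measured compounds named here, compound 1 and compound 2 differ in more than one place, so no matched step for this change is available from the measured compounds. The expectation for the step is a change that stays within the scatter, if anything toward a lower number: a 1.1-fold lower number from compound 2 to compound 3 (0.05 log units; within the scatter). For compound 3 the estimated inhibition constant is 15 nM, with a range from 5 nM to 45 nM.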

Compound 3, inhibition constant: 30 nM
Estimate against measurement, compound 3: 2.0-fold (0.30 log units) below; low and high end bracket the measured number.
By their numbers in this assay, from the lowest: compounds 2, 1 and 3 (each within the scatter of the next).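

In this assay, the change from phenyl to 3,4-dichlorophenyl on a saturated ring carbon now has its first matched step, a 1.8-fold higher number from compound 2 to compound 3 (0.25 log units; within the scatter). This position of the six-membered non-aromatic ring with 2 nitrogen therefore accepts the two added chlorine atoms without a difference that can be relied on, although this rests on a single pair. Nothing on hand accounts for this outcome or links it to any property of either group.

Going by these compounds, it remains open whether a phenyl carrying a single chlorine, a methoxyphenyl or a pyridine ring on this carbon would move the number beyond the scatter. It also remains open whether the same exchange would give a comparable step on the core of compound 1, where no phenyl partner is shown.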